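Working notes: a further chain double bond on compound 2

A few compounds are considered here, and "the series" means these few. Any claim that something is new, unique, unknown or untested is made for them only; others in the source may bear on it.

In a functional assay on MCF7 cells (Homo sapiens) for antiproliferative activity, read by MTT assay (a higher number here means a weaker inhibitor, a lower number a stronger inhibitor), compound 1 (`CCCCC/C=C\C/C=C\CCCCCCCc1cc(=O)c2c(O)c(C)c(O)cc2o1`) gives > 84100 nM as a limit and not a number. For the measured compounds named here, compound 2 (`CCCCC/C=C\C/C=C\CCCCCCCC1(O)CC(=O)c2c(O)c(C)c(O)c(C)c2O1`) gives 43200 nM as the only actual number so far, so it has no measured neighbour to be ranked against.

Compound 3 (`CC/C=C\C/C=C\C/C=C\CCCCCCCC1(O)CC(=O)c2c(O)c(C)c(O)c(C)c2O1`) carries but-1-en-1-yl in place of butyl on a saturated chain carbon bound to a double-bonded chain carbon and otherwise matches compound 2. Going by the values given here, no step between measured compounds is available to size this change. Starting from compound 2 at 43200 nM in this assay a shift beyond the scatter is not expected in either direction. The estimated 1.1-fold lower number from compound 2 to compound 3 (0.06 log units; within the scatter) is accordingly small. For compound 3 the estimate is 38000 nM with an expected range from 16000 nM to 85000 nM in this series.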

Compound 3, half-maximal inhibitory concentration: 43200 nM
For compound 3 the middle estimate is 1.1-fold (0.06 log units) below the measured one; low and high end bracket the measured number.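

In this assay this position now has its first readable step, which shows no change at the digits printed from compound 2 to compound 3 (within the scatter). The change of butyl to but-1-en-1-yl on a saturated chain carbon bound to a double-bonded chain carbon adds one double bond outside aromatic rings and keeps the same count of heavy atoms, and this single pair shows that the change leaves the read-out unmoved. Compound 1 remains a limit and not a number, and no step to it can be read: the limit of > 84100 nM in this assay, at which 1 of the 3 values shown sits.

Whether any change at this place can move the read-out remains open, as the one step shown is a swap between two unbranched four-carbon groups. A longer chain, an amine or a carboxylic acid in place of but-1-en-1-yl would test this position more widely.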